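Swapping the aryl ketone substituent on an indole hydroxamate

The source may hold more compounds than are shown below. What is called first, only, known or untested is meant among the compounds shown, and "the series" means these compounds.

Measured compounds:
- compound 1, `COc1ccc(C(=O)c2ccc3c(ccn3Cc3ccc(C(=O)NO)cc3)c2)cc1OC`: 18900 nM
- compound 2, `COc1ccc(C(=O)c2ccc3c(ccn3Cc3ccc(/C=C/C(=O)NO)cc3)c2)cc1`: 7050 nM
- compound 3, `COc1cc(C(=O)c2ccc3c(ccn3Cc3ccc(C(=O)NO)cc3)c2)cc(OC)c1OC`: "not determined" (no result reported)

In an assay on isolated protein for inhibition of polyamine deacetylase HDAC10 (Homo sapiens) (on this read-out lower numbers stand for stronger inhibition and higher numbers for weaker inhibition), compound 1 gives 18900 nM, the highest of the two numbers available. Compound 2 gives 7050 nM in this assay, a lower number that lies beyond the usual scatter, but compound 2 differs from compound 1 in more than one place, so no single change can be credited. For compound 3 this assay reports "not determined" (no result reported), so no number is available for it.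

Compound 4, `O=C(NO)c1ccc(Cn2ccc3cc(C(=O)c4ccc(Cl)cc4)ccc32)cc1`, keeps the shared core of compound 1 and differs only as follows: 4-chlorophenyl in place of 3,4-dimethoxyphenyl on a carbonyl carbon. Among the measured compounds shown here, no measured pair shows this exact change, so the expected step from compound 1 to compound 4 is small, a 1.3-fold lower number from compound 1 to compound 4 (0.10 log units; within the scatter), with no clear direction beyond the scatter. Compound 4 is therefore estimated at 15000 nM in this assay, within a range from 5000 nM to 45000 nM.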

Compound 4, half-maximal inhibitory concentration: > 100000 nM
Compound 4 was reported as a limit (the forecaster's own chance of this, stated with the estimate: 10%); middle value at least 6.6-fold (0.82 log units) away from the limit.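

Among the compounds shown here, this is the first single change that can be read at this position: in this assay, 4-chlorophenyl in place of 3,4-dimethoxyphenyl on a carbonyl carbon gives an at least 5.2-fold higher number from compound 1 to compound 4 (0.72 log units; beyond the scatter). The aryl group on this carbonyl carbon therefore does affect the read-out, and this swap moves it towards weaker inhibition. The true size of the step stays open, since compound 4 is reported as a limit of the assay and not as a number: the limit of > 100000 nM in this assay, at which 1 of the 4 values shown sits.

Whether losing the two methoxy groups or gaining the chlorine drives the step remains unclear. A plain phenyl on the same carbonyl carbon would help separate the two.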